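Dichloro variant of the pyrazole carboxylic acid series

This account rests on a few compounds, and the source may have more. Where it says the series, first, only, none or still open, it means among the compounds named here.

Among the measured compounds shown here, compound 1 `CCCCc1nn(-c2cccc(Cl)c2)c(C(=O)O)c1Cc1ccc(-c2ccccc2-c2nn[nH]n2)cc1` and compound 2 `CCCCc1nn(-c2ccccc2Cl)c(C(=O)OCC)c1Cc1ccc(-c2ccccc2-c2nn[nH]n2)cc1` are the two members measured so far in an assay on isolated protein for inhibition of Dipeptidase 1 (Sus scrofa); on this read-out higher numbers stand for weaker inhibition and lower numbers for stronger inhibition. Compound 1 gives 425000 nM in this assay, and compound 2 gives 250000 nM; the two numbers lie within the scatter of each other, so compound 1 does not stand apart from compound 2 on the values at hand. The two differ in more than one place, so no single step can be read from them. Compound 3 `CCCCc1nn(-c2cccc(Cl)c2Cl)c(C(=O)O)c1Cc1ccc(-c2ccccc2-c2nn[nH]n2)cc1` has not been measured. Compared with compound 1 it carries chloro in place of hydrogen on an aromatic carbon. With no measured step of this kind in the series, the expectation for compound 3 is a step from compound 1 of a 1.1-fold lower number from compound 1 to compound 3 (0.05 log units; within the scatter) in this assay, that is, nothing beyond the scatter in either direction. Compound 3 is therefore estimated at 380000 nM, with a range from 130000 nM to 1100000 nM.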

Compound 3, inhibition constant: 310000 nM
For compound 3 the middle estimate is 1.2-fold (0.09 log units) above the measured one; low and high end bracket the measured number.
By their numbers in this assay, from the lowest: compounds 2, 3 and 1 (each within the scatter of the next).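

In this assay, among the compounds shown here, the change from 3-chlorophenyl to 2,3-dichlorophenyl gives the first step that can be read at a single place: a 1.4-fold lower number from compound 1 to compound 3 (0.14 log units; within the scatter) for chloro in place of hydrogen on an aromatic carbon. At this place, ortho to a chloro group and ortho to a large group, one added chlorine thus leaves the number within the scatter, on the acid form of the shared core. No measurement bearing on this result is available to interpret it.

On these data alone, whether a different group here, such as methoxy, an amine or a nitrile, would move the number beyond the scatter remains open. As far as these compounds go, the steps between compound 2 and the two acids cannot be read, so the ester-to-acid change on an otherwise identical compound also stays open.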